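Urea acid series: carboxylic acid to primary amide

The source may hold more compounds than are shown below. What is called first, only, known or untested is meant among the compounds shown, and "the series" means these compounds.

Measured compounds in an ADME assay on microsomes from liver (Homo sapiens) for metabolic stability, using NADPH, with a stated time of 60 min; on this read-out higher numbers stand for fast clearance and lower numbers for slow clearance:
compound 1 `CC(C)(NC(=O)Nc1ccc(F)c(C(F)(F)F)c1)C(=O)O`; compound 1 gives < 7 uL/min, a limit of the assay.
compound 2 `CC(C)(CC(=O)Nc1ccc(F)c(C(F)(F)F)c1)C(=O)O`; compound 2 gives < 7 uL/min, a limit of the assay.
compound 3 `O=C(Nc1ccc(F)c(C(F)(F)F)c1)NC1(C(=O)O)CC1`; compound 3 gives < 7 uL/min, a limit of the assay.

All three measured values sit together at the limit of < 7 uL/min in this assay, at which 3 of the 3 values shown sit, so no number separates them. The steps between them are accordingly unreadable: a step that the two limits leave unreadable from compound 1 to compound 2, a step that the two limits leave unreadable from compound 1 to compound 3 and a step that the two limits leave unreadable from compound 2 to compound 3. Compound 3 therefore stands at the limit with no value of its own and nothing to rank it against compound 1 or compound 2.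

Compound 4 `CC(C)(NC(=O)Nc1ccc(F)c(C(F)(F)F)c1)C(N)=O` differs from compound 3 by 1-carbamoyl-1-methylethyl in place of 1-carboxycyclopropyl on an amide-type nitrogen. Going by the values given here, none of the measured steps touches the carboxylic acid, since every measured compound keeps it; they tell only that compound 3 shares the limit with the rest. The expected step of an at least 1.4-fold higher number from compound 3 to compound 4 (0.15 log units; that floor lies within the scatter) is therefore taken as small, possibly within the scatter. Compound 4 is expected to give 10 uL/min in this assay, with a range from 5 uL/min to 25 uL/min, and a fair chance that only the limit is reported.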

Compound 4, intrinsic clearance in a liver preparation (reported as CLH), per the amount of preparation that the assay uses in the Homo sapiens assay: 19 uL/min
Compound 4: middle estimate off by 1.9-fold (0.28 log units), on the low side; measured number inside the range.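

Going by these compounds alone, with the primary amide, the Homo sapiens assay gives the first readable steps: an at least 2.7-fold higher number from compound 1 to compound 4 (0.43 log units; beyond the scatter) for amino in place of hydroxy on a carbonyl carbon, an at least 2.7-fold higher number from compound 3 to compound 4 (0.43 log units; beyond the scatter) and an at least 2.7-fold higher number from compound 2 to compound 4 (0.43 log units; beyond the scatter), whereas the steps among the three acids cannot be read. In a physicochemical assay for solubility, read by nephelometry, measured as kinetic solubility, at pH 2, tested at 10 mg/mL (on this read-out higher numbers stand for higher solubility and lower numbers for lower solubility), compound 3 gives > 100 ug/mL, a limit of the assay. In the physicochemical assay compound 4 gives 50 ug/mL, a measured number, and the step on this change reads an at least 2.0-fold lower number from compound 3 to compound 4 (0.30 log units; that floor lies within the scatter).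

As far as these compounds go, the full size of the steps in the Homo sapiens assay stays open because the acids give no number of their own: the limit of < 7 uL/min in the Homo sapiens assay, at which 3 of the 4 values shown sit. Also open is whether a nitrile or a methyl ester in place of the primary amide would sit at the limit with the acids or read as high as the amide.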